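Methoxy in Place of Fluoro on Compound 1

The source may hold more compounds than are shown below. What is called first, only, known or untested is meant among the compounds shown, and "the series" means these compounds.

Compound 1 `CCCCNc1nc(N)nnc1OCc1ccccc1F` gives 560 nM in an assay on isolated protein for agonist activity at Toll-like receptor 8 (Homo sapiens); a higher number here means that more compound is needed for the effect, a lower number that less compound is needed; only compound 2 `CCCCNc1nc(N)nnc1OCCOC` stands beside it, with 1000 nM, and the step of a 1.8-fold higher number from compound 1 to compound 2 (0.25 log units; within the scatter) sits within the scatter. Compound 3 `CCCCNc1nc(N)nnc1OCc1ccccc1OC` differs from compound 1 by methoxy in place of fluoro on an aromatic carbon. Among the compounds with values here, no measured step alters a substituent on this ring; the one step known replaces the whole group and yet stays within the scatter, so no change beyond the scatter is expected in this assay. Compound 3 is therefore expected to give 560 nM, between 250 nM and 1250 nM, a step of no change at the digits printed from compound 1 to compound 3 (within the scatter).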

Compound 3, half-maximal effective concentration: 640 nM
Compound 3: middle estimate off by 1.1-fold (0.06 log units), on the low side; the measured number falls inside the stated range.
By their numbers in this assay, from the lowest: compounds 1, 3 and 2 (each within the scatter of the next).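

Within the data shown here, this is the first measured step that alters a substituent on the ring rather than replacing the whole group: methoxy in place of fluoro on an aromatic carbon, ortho to a large group, gives a 1.1-fold higher number from compound 1 to compound 3 (0.06 log units; within the scatter) in this assay. The entering methoxy brings one more heavy atom and a hydrogen-bond acceptor, yet the step stays within the scatter. No measurement at hand speaks to why this substituent change leaves the number where it is.

From the compounds shown here alone, whether an amine or a carboxylic acid on this same aromatic carbon would also stay within the scatter remains open. So does whether a longer chain in place of the methoxy would do so.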